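The source may report more compounds than this note shows. Statements on the series, on what has been measured and on what is new or still open speak of the compounds shown alone.

In a functional assay on HT-29 cells (Homo sapiens) for cytotoxicity, read by MTT assay, with a stated time of 72 h (on this read-out higher numbers stand for weaker inhibition and lower numbers for stronger inhibition), compound 1 (`COc1ccc(-c2c(-c3cc(Br)c(OC)c(OC)c3)ncn2C)cc1F`) gives 510 nM, a clear measured potency. Compound 2 (`COc1ccc(-c2c(-c3cc(N)c(OC)c(OC)c3)ncn2C)cc1O`) reads > 10000 nM, which is a limit of the assay and not a number. Going by these compounds, this places compound 2 at the limit of > 10000 nM in this assay, at which 1 of the 2 values shown sits, so its true value is unknown.

Compound 3 (`COc1ccc(-c2c(-c3cc(N)c(OC)c(OC)c3)ncn2C)cc1F`) differs from compound 2 in one place: fluoro in place of hydroxy on an aromatic carbon, ortho to a methoxy group (fluoro in place of hydroxy on an aromatic carbon). For the measured compounds named here, no measured pair shows this change on its own, so any forecast is rough. Fluoro is also present on compound 1, which gives 510 nM, so a move toward stronger inhibition is expected in this assay. The estimated change is an at least 5.0-fold lower number from compound 2 to compound 3 (0.69 log units; beyond the scatter), and its true size remains uncertain while compound 2 has only a limit. For compound 3, the expected value is 2000 nM, with an estimated range of 300 nM to 10000 nM.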

Compound 3, half-maximal inhibitory concentration: > 50000 nM
Compound 3: a limit, no number; the forecaster's own chance of this, stated with the estimate: 25%; at least 25-fold (1.39 log units) between middle value and limit.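

In this assay compound 3 reads > 50000 nM as a limit of the assay and not a number, so fluoro at this place, ortho to a methoxy group, does not bring back a measurable potency while the amino group stays. Compound 2 also ends in a limit, so the step between these two cannot be read. For the compounds shown here, the readable change lies at the other place: with fluoro kept, amino in place of bromo on an aromatic carbon gives an at least 98-fold higher number from compound 1 to compound 3 (1.99 log units; beyond the scatter) and this large step is the first sign of how much that place matters on this read-out.

Going by these compounds, how far compound 2 and compound 3 truly lie beyond their limits stays open, and so does any real difference between hydroxy and fluoro at this place. Also open, on these data alone, is how a chloro group or a methyl group would read in place of the amino group, which would show whether bromo itself is needed.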